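The source may hold more compounds than are shown below. What is called first, only, known or untested is meant among the compounds shown, and "the series" means these compounds.

Measured in an assay on isolated protein for inhibition of histone deacetylase 8 (Homo sapiens), read by mobility shift assay; a lower number here means a stronger inhibitor, a higher number a weaker inhibitor:
compound 1 `O=C(NO)c1ccc(CN(Cc2ccc(F)cc2)S(=O)(=O)c2c(F)c(F)c(F)c(F)c2F)cc1`: 367 nM
compound 2 `O=C(NO)c1ccc(CN(Cc2ccc(C(F)(F)F)cc2)S(=O)(=O)c2c(F)c(F)c(F)c(F)c2F)cc1`: > 1000 nM, a limit of the assay rather than a number.

Compound 2 thus stands at the limit of this assay, as the limit of > 1000 nM in this assay, at which 1 of the 2 values shown sits, records, and only a range is known for it. Among the compounds with values here, the single measured step, an at least 2.7-fold higher number from compound 1 to compound 2 (0.43 log units; beyond the scatter), runs into that limit, so its true size is open. Compound 3 `CN(C)c1ccc(CN(Cc2ccc(C(=O)NO)cc2)S(=O)(=O)c2c(F)c(F)c(F)c(F)c2F)cc1` differs from compound 2 by dimethylamino in place of trifluoromethyl on an aromatic carbon. Within the data shown here, no measured step involves dimethylamino; the only guidance is that this position carried fluoro in compound 1 at 367 nM. With trifluoromethyl in its place, compound 2 is known only as a limit of the assay. Whether exchanging trifluoromethyl for dimethylamino brings the number back toward that of compound 1 or leaves it at the limit cannot be read from the data. The estimate for compound 3 is 800 nM (range 300 nM to 3000 nM), an expected at least 1.2-fold lower number from compound 2 to compound 3 (0.09 log units; that floor lies within the scatter), with the direction uncertain.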

Compound 3, half-maximal inhibitory concentration: > 1000 nM
Compound 3: only a limit was reported; the forecaster's own chance of this, stated with the estimate: 45%; at least 1.2-fold (0.09 log units) between middle value and limit.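

Compound 3 gives > 1000 nM, a limit of the assay and not a number. In this assay, dimethylamino in place of fluoro gives an at least 2.7-fold higher number from compound 1 to compound 3 (0.43 log units; beyond the scatter), so the loss at this position is not particular to trifluoromethyl: two different replacements of fluoro both end at the limit, and fluoro alone among the three groups shown gives a measured number. The step from compound 2 to compound 3 cannot be read, and the two groups cannot be ranked against each other: the limit of > 1000 nM in this assay, at which 2 of the 3 values shown sit.

From the compounds shown here alone, how far compound 2 and compound 3 each lie past the limit remains open. Also open, going by these compounds, is whether a group such as chloro, methoxy or a primary amine on this aromatic carbon would keep the number near that of compound 1 or also reach the limit.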